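Anilides on a shared core: a 1-chloroethyl variant

The source may report more compounds than this note shows. Statements on the series, on what has been measured and on what is new or still open speak of the compounds shown alone.

Measured so far:
Compound 1 `C=CC(=O)Nc1cccc(-c2nc3ccccc3s2)c1`: in an ADME assay on Raji cells (Homo sapiens) for inhibition, with a stated time of 72 h (a lower number here means that less compound is needed, a higher number that more compound is needed for the effect), compound 1 gives > 25000 nM, a limit.
Compound 2 `C/C=C/C(=O)Nc1cccc(-c2nc3ccccc3s2)c1`: compound 2 gives > 25000 nM, a limit.
Compound 3 `C=C(C)C(=O)Nc1cccc(-c2nc3ccccc3s2)c1`: compound 3 gives > 25000 nM, a limit.

Compound 2 stands at the limit of this assay, as do the two other values, which is what the limit of > 25000 nM in this assay, at which 3 of the 3 values shown sit, records. The change to compound 4 `CC(Cl)C(=O)Nc1cccc(-c2nc3ccccc3s2)c1` is 1-chloroethyl in place of prop-1-en-1-yl on a carbonyl carbon. The measured steps a step that the two limits leave unreadable from compound 1 to compound 2, a step that the two limits leave unreadable from compound 1 to compound 3 and a step that the two limits leave unreadable from compound 2 to compound 3 all run between limits and give no readable size, so no direction can be drawn for the expected step that the limit leaves unreadable from compound 2 to compound 4. Compound 4 is therefore estimated to give 30000 nM, with a range from 8000 nM to 120000 nM, most probably reported again as a limit.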

Compound 4, half-maximal effective concentration: > 25000 nM
Compound 4 ended at the assay's limit (the forecaster's own chance of this, stated with the estimate: 80%); the middle value lies beyond the limit too.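

The steps from compound 4 to compound 1, compound 2 and compound 3 cannot be read, since all four compounds sit at a limit: the limit of > 25000 nM in this assay, at which 4 of the 4 values shown sit.

The compounds shown leave open how vinyl, prop-1-en-1-yl, 1-methylethenyl and 1-chloroethyl on the carbonyl carbon compare in this assay.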